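This account rests on a few compounds, and the source may have more. Where it says the series, first, only, none or still open, it means among the compounds named here.

Measured in an assay on HEK293 cells for inhibition of N-acylethanolamine-hydrolyzing acid amidase (Homo sapiens), read by fluorescence, with stated times of 10 min and 50 min; a higher number here means a weaker inhibitor, a lower number a stronger inhibitor: compound 1 `COC(=O)N1C[C@H](NC(=O)OCCCCC2CCCCC2)C1=O` gives 7180 nM; compound 2 `CCCCCON1C(=O)[C@@H](NC(=O)OCCCCC2CCCCC2)[C@@H]1C` gives 387 nM; compound 3 `CCOCCON1C(=O)[C@@H](NC(=O)OCCCCC2CCCCC2)[C@@H]1C` gives 187 nM.

Compound 3 holds the lowest number of the three. Going by the values given here, its nearest neighbour is compound 2, reached by a 2.1-fold lower number from compound 2 to compound 3 (0.32 log units; beyond the scatter); compound 1 lies far higher on the values alone, no single-point step joining the two.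

Compound 4 `CC(=O)CCCON1C(=O)[C@@H](NC(=O)OCCCCC2CCCCC2)[C@@H]1C` differs from compound 3 by 2-oxopropyl in place of ethoxy on a saturated chain carbon, two bonds along the chain from an oxygen on an unsaturated carbon. Among the compounds with values here, the only step at that position is a 2.1-fold lower number from compound 2 to compound 3 (0.32 log units; beyond the scatter), a modest change when an oxygen was introduced into the chain; here the chain keeps one acceptor and grows by one atom. In this assay compound 4 is therefore expected to sit close to compound 3, with a 1.3-fold higher number from compound 3 to compound 4 (0.13 log units; within the scatter) at most modest and of uncertain direction. The estimate for compound 4 is 250 nM within 90 nM to 700 nM.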

Compound 4, half-maximal inhibitory concentration: 75 nM
Beside the measured number, compound 4's estimate is 3.3-fold (0.52 log units) above it; the measured number lies below the stated range.
By their numbers in this assay, from the lowest: compound 4; then compound 3; then compound 2; then compound 1.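

In this assay, 2-oxopropyl in place of ethoxy on this saturated chain carbon gives a 2.5-fold lower number from compound 3 to compound 4 (0.40 log units; beyond the scatter) with one hydrogen-bond acceptor on each side of the change, so the acceptor count alone does not set the number. Against the all-carbon chain, acetyl in place of ethyl gives a 5.2-fold lower number from compound 2 to compound 4 (0.71 log units; beyond the scatter) and places the ketone chain of compound 4 lowest of the series. Nothing available explains this gain.

Still open, going by these compounds, is whether the carbonyl or the chain length carries the change. A carboxylic acid or an amine at the same chain end, or a longer chain ending in acetyl, would test this.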